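The source may hold more compounds than are shown below. What is called first, only, known or untested is meant among the compounds shown, and "the series" means these compounds.

Of the compounds shown here, two of a shared core have been measured so far. Compound 1 `CC(Oc1ccccc1-c1ccc([N+](=O)[O-])cc1)C1=NCCN1` in an assay on CHO cells for displacement of a labelled ligand from Alpha-2C adrenergic receptor (Homo sapiens) (a higher number here means a weaker inhibitor, a lower number a stronger inhibitor), gives 302 nM. Compound 2 `CC(Oc1ccccc1-c1ccncc1)C1=NCCN1` in this assay gives 1450 nM, the higher of the two numbers recorded, and the gap between compound 2 and compound 1 lies beyond the usual scatter of this assay. For the measured compounds named here, no further step between measured compounds is available, so the account rests on these two values alone.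

Compound 3 `CC(Oc1ccccc1-c1cccs1)C1=NCCN1` has not yet been measured. It differs from compound 2 in one place: thiophen-2-yl in place of pyridin-4-yl on an aromatic carbon. Within this small set, the two measured values show only that the group on that aromatic carbon can shift the number by more than the scatter, with the pyridin-4-yl compound 2 standing weaker than the nitrophenyl compound 1.

For compound 3 a step toward a lower number in this assay is expected, of moderate size, since thiophen-2-yl is a change away from the group carried by compound 2 with its 1450 nM. The estimate for compound 3 in this assay is 550 nM, with a range from 150 nM to 2000 nM, which corresponds to an expected step of a 2.6-fold lower number from compound 2 to compound 3 (0.42 log units; beyond the scatter).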

Compound 3, inhibition constant: 72.4 nM
Compound 3: middle estimate off by 7.6-fold (0.88 log units), on the high side, and the stated range ends above it.
By their numbers in this assay, from the lowest: compound 3; then compound 1; then compound 2.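

In this assay the exchange of pyridin-4-yl for thiophen-2-yl on this aromatic carbon gives a 20-fold lower number from compound 2 to compound 3 (1.30 log units; beyond the scatter) and so makes a large step, much more than the earlier pair alone showed this position could yield. The counted donors and acceptors stay the same across the change, while the ring goes from six-membered to five-membered and the hetero atom from nitrogen to sulfur, so a large shift here does not require any change in those counts. With compound 1 at 302 nM and compound 3 at 72.4 nM in the same assay, the nitrophenyl group no longer carries the lowest number of the set, and nothing at hand accounts for the size of the step.

The compounds shown do not separate the part played by ring size from that of the hetero atom, a question that furan-2-yl, thiophen-3-yl or an unsubstituted phenyl at this place would bear on. They also leave open how far the number would move with an amine or a methoxy group on the thiophene ring.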